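Changing the aromatic group on a shared piperazine-type core

A few compounds are considered here, and "the series" means these few. Any claim that something is new, unique, unknown or untested is made for them only; others in the source may bear on it.

Three compounds built on one shared core were tested in an assay on isolated protein for binding affinity to Adrenergic receptor alpha-1 (Rattus norvegicus), read by radioligand binding; on this read-out lower numbers stand for stronger inhibition and higher numbers for weaker inhibition. Compound 1 `COc1ccccc1N1CCN(CN2C(=O)C3CCCN3C2=O)CC1` gives 500 nM. Compound 2 `COc1ccccc1N1CCN(CN2C(=O)C3CCCCN3C2=O)CC1` reaches only a limit of the assay, > 1000 nM, so no exact number is known for it. Compound 3 `O=C1C2CCCCN2C(=O)N1CN1CCN(c2cccc(C(F)(F)F)c2)CC1` likewise stops at a limit, > 1000 nM. Compound 2 therefore stands at the edge of what this assay can report, a position shared by two of the three values shown (the limit of > 1000 nM in this assay, at which 2 of the 3 values shown sit). The new compound 4 `O=C1C2CCCCN2C(=O)N1CN1CCN(c2ccc([N+](=O)[O-])cc2)CC1` differs from compound 2 in one place: 4-nitrophenyl in place of 2-methoxyphenyl on an amine nitrogen in a ring. Going by the values given here, no measured pair of compounds shows exactly this swap, so the size of the step cannot be read directly from the data. Compound 3, which carries a different aromatic group on the same core, also ends at the limit, and the step from compound 2 to compound 4 is expected to be none beyond the usual scatter, in either direction: a step that the limit leaves unreadable from compound 2 to compound 4. Compound 4 is thus estimated at 3000 nM, within a range from 1000 nM to 20000 nM.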

Compound 4, inhibition constant: > 10000 nM
Compound 4 was reported as a limit; the forecaster's own chance of this, stated with the estimate: 75%; middle value at least 3.3-fold (0.52 log units) from the limit.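

Compound 2 and compound 4 both end at limits rather than exact numbers, so the size of the step between them cannot be read. From the compounds shown here alone, how strongly either compound binds, and whether 4-nitrophenyl and 2-methoxyphenyl truly differ on this core, remains open.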